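From 2-bromophenyl to 4-(dimethylamino)phenyl: what to expect

The source may hold more compounds than are shown below. What is called first, only, known or untested is meant among the compounds shown, and "the series" means these compounds.

Three close relatives sharing one core have been tested in a functional assay on DU-145 cells (Homo sapiens) for cytotoxicity, read by sulforhodamine B assay, with a stated time of 48 h; on this read-out lower numbers stand for stronger inhibition and higher numbers for weaker inhibition. Compound 1 `C[C@H]1CC[C@@H]2[C@@H](OC(=O)[C@]23CC(c2c(Cl)cccc2Cl)=NO3)[C@]2(C)C(=O)C=C[C@@]12O` gives 38000 nM, and compound 2 `C[C@H]1CC[C@@H]2[C@@H](OC(=O)[C@]23CC(c2ccc(Cl)cc2)=NO3)[C@]2(C)C(=O)C=C[C@@]12O` gives 43000 nM. Compound 3 `C[C@H]1CC[C@@H]2[C@@H](OC(=O)[C@]23CC(c2ccccc2Br)=NO3)[C@]2(C)C(=O)C=C[C@@]12O` gives 18000 nM, the lowest of the three numbers and so the strongest inhibition of the set.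

The next compound, compound 4 `C[C@H]1CC[C@@H]2[C@@H](OC(=O)[C@]23CC(c2ccc(N(C)C)cc2)=NO3)[C@]2(C)C(=O)C=C[C@@]12O`, keeps the core and changes only the aromatic group: 4-(dimethylamino)phenyl in place of 2-bromophenyl on a carbon with a double bond to nitrogen. It carries 4-(dimethylamino)phenyl in place of 2-bromophenyl on a carbon with a double bond to nitrogen. Going by the values given here, no tested compound has a dimethylamino group, so the guidance is indirect.

All three measured steps are swaps at this same place. The change in a 1.1-fold higher number from compound 1 to compound 2 (0.05 log units; within the scatter) lies within the scatter, while a 2.1-fold lower number from compound 1 to compound 3 (0.32 log units; beyond the scatter) and a 2.4-fold lower number from compound 2 to compound 3 (0.38 log units; beyond the scatter) are modest. Both modest steps favour the 2-bromophenyl group, so leaving it may give back a similar amount. The nearest comparison is compound 2 at 43000 nM, whose 4-chlorophenyl group is also named at the 4 position.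

The expected change is a modest rise, a 2.1-fold higher number from compound 3 to compound 4 (0.32 log units; beyond the scatter). Compound 4 is estimated at 38000 nM, with an expected range from 15000 nM to 85000 nM.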

Compound 4, half-maximal inhibitory concentration: 4500 nM
Estimate against measurement, compound 4: 8.4-fold (0.93 log units) above; measured number outside the range, below it.
By their numbers in this assay, from the lowest: compound 4; then compound 3; then compounds 1 and 2 (each within the scatter of the next).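

Among the four compounds, the aromatic group on the carbon with a double bond to nitrogen matters more than the three halogen-bearing groups suggested: in this assay, replacing 2-bromophenyl with 4-(dimethylamino)phenyl gives a 4.0-fold lower number from compound 3 to compound 4 (0.60 log units; beyond the scatter), which makes compound 4 the strongest inhibitor of the set. The cleanest comparison is with compound 2, where only the group on the same aromatic carbon changes, dimethylamino in place of chloro, and this gives a 9.6-fold lower number from compound 2 to compound 4 (0.98 log units; beyond the scatter), while the comparison with the doubly chlorinated ring gives an 8.4-fold lower number from compound 1 to compound 4 (0.93 log units; beyond the scatter). So a substituent at the 4 position is not enough to set the number, since the 4-chlorophenyl and 4-(dimethylamino)phenyl compounds lie far apart, and compound 4 is also the only one here whose ring carries no halogen.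

The data at hand offer no measurement that explains this gain. On these data alone, with a single compound of this kind, it remains open whether the gain belongs to the dimethylamino group itself or would also appear with a simple primary amine, a methoxy group, or an unsubstituted phenyl ring at this place.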